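The source may report more compounds than this note shows. Statements on the series, on what has been measured and on what is new or still open speak of the compounds shown alone.

Compound 2 `Cn1ccc(S(=O)(=O)Nc2cccc(NC(=O)COc3ccc4c(=O)ccoc4c3)c2)n1` carries the same core as compound 1 `O=C(COc1ccc2c(=O)ccoc2c1)Nc1cccc(NC(=O)c2ccc([N+](=O)[O-])cc2)c1`, which in an assay on isolated protein for inhibition of Rho-associated protein kinase 1 (Homo sapiens), read by scintillation counting, radiometric assay and 33P incorporation, with a stated time of 40 min, in the presence of a further agent that is not named here (on this read-out higher numbers stand for weaker inhibition and lower numbers for stronger inhibition), gives 67 nM. In this assay compound 2 gives only a limit, > 10000 nM. Going by these compounds, compound 2 thus stands at the limit of > 10000 nM in this assay, at which 1 of the 2 values shown sits, so its true value is unknown beyond that. Going by the values given here, the single measured step, an at least 140-fold higher number from compound 1 to compound 2 (2.17 log units; beyond the scatter), exchanged a nitrobenzoyl amide for a methylpyrazolyl sulfonamide on a ring nitrogen, so it folds together two changes: the carbonyl became a sulfonyl, and a six-membered carbon ring became a five-membered ring with two hetero atoms.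

Compound 3 `CC(C)(C)c1ccc(S(=O)(=O)Nc2cccc(NC(=O)COc3ccc4c(=O)ccoc4c3)c2)cc1` differs from compound 2 by 4-(tert-butyl)phenyl in place of 1-methyl-1H-pyrazol-3-yl on a sulfonyl sulfur. This change undoes only one of the two parts of that measured step: a six-membered carbon-only ring returns, while the sulfonamide stays. Among the compounds with values here, only that one step bears on the change, and it was large, so some of the lost inhibition is expected to return, but how much of it rests on the ring rather than the sulfonyl link cannot be told from these two compounds. A step of moderate size toward stronger inhibition, an at least 3.3-fold lower number from compound 2 to compound 3 (0.52 log units; beyond the scatter), is expected. Compound 3 is estimated at 3000 nM, with a range from 500 nM to 20000 nM.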

Compound 3, half-maximal inhibitory concentration: > 10000 nM
Compound 3 gave a limit, no number; the forecaster's own chance of this, stated with the estimate: 40%; at least 3.3-fold (0.52 log units) between middle value and limit.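

Going by these compounds alone, compound 2 and compound 3 both end at a limit of the assay rather than a number, so no step between them can be read: the limit of > 10000 nM in this assay, at which 2 of the 3 values shown sit. The compounds shown leave open how far the true values of compound 2 and compound 3 lie beyond that limit, and which of 1-methyl-1H-pyrazol-3-yl and 4-(tert-butyl)phenyl on a sulfonyl sulfur gives stronger inhibition.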